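A few compounds are considered here, and "the series" means these few. Any claim that something is new, unique, unknown or untested is made for them only; others in the source may bear on it.

Compound 1 `CC(C)(C)C(=O)NCCCCN1CCN(c2ccc(Cl)cc2)CC1` in an assay on HEK293 cells for binding affinity to D(4) dopamine receptor (Homo sapiens), read by radioligand binding (on this read-out higher numbers stand for weaker inhibition and lower numbers for stronger inhibition), gives 12.6 nM. Compound 2 `CC(=O)NCCCCN1CCN(c2ccc(Cl)cc2)CC1` gives 1260 nM. Compound 3 `CCC(C)(C)C(=O)NCCCCN1CCN(c2ccc(Cl)cc2)CC1` gives 15.9 nM.

Compound 3 stands second highest of the three numbers; its nearest neighbour is compound 1, within the scatter, and its furthest is compound 2. Compound 4 `CCCC(C)(C)C(=O)NCCCCN1CCN(c2ccc(Cl)cc2)CC1` differs from compound 3 by methyl in place of hydrogen on a saturated chain carbon, three bonds along the chain from a carbonyl carbon. The step that most resembles this, a 1.3-fold higher number from compound 1 to compound 3 (0.10 log units; within the scatter), also added a methyl to the chain and stayed within the scatter. The large steps of a 100-fold higher number from compound 1 to compound 2 (2.00 log units; beyond the scatter) and a 79-fold lower number from compound 2 to compound 3 (1.90 log units; beyond the scatter) concern the exchange of methyl for a bulkier group on the carbonyl carbon and bear less on the present change. Compound 4 is therefore expected to show a step of a 1.3-fold higher number from compound 3 to compound 4 (0.10 log units; within the scatter), within the scatter. The estimate for compound 4 is 20 nM, ranging from 8 nM to 50 nM.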

Compound 4, inhibition constant: 12.6 nM
The estimate for compound 4 lay 1.6-fold (0.20 log units) above the measured number; the measured number falls inside the stated range.
By their numbers in this assay, from the lowest: compounds 1, 4 and 3 (each within the scatter of the next); then compound 2.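

In this assay the methyl added three bonds along the chain from the carbonyl carbon gives a 1.3-fold lower number from compound 3 to compound 4 (0.10 log units; within the scatter) and the ethyl added two bonds along gives no change at the digits printed from compound 1 to compound 4 (within the scatter) so lengthening 1,1-dimethylpropyl to 1,1-dimethylbutyl stays within the scatter. The large gap seen with the shorter groups also persists with 1,1-dimethylbutyl in place of methyl on the carbonyl carbon, with a 100-fold lower number from compound 2 to compound 4 (2.00 log units; beyond the scatter) as the step. Nothing given here explains why the number holds along this chain.

The compounds shown leave open how far this holds, whether for 1,1-dimethylpentyl or a longer chain, or for a hydroxyl group at the chain end.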